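The source may report more compounds than this note shows. Statements on the series, on what has been measured and on what is new or still open speak of the compounds shown alone.

Going by the values given here, in an ADME assay on HUVEC cells (Homo sapiens) for antiproliferative activity, read by resazurin assay, with a stated time of 72 h (a lower number here means a stronger inhibitor of growth, a higher number a weaker inhibitor of growth), three compounds have numbers so far. Compound 1 `CCCCCCCCCCCC/C=C\N(NC(=O)COC)C(=O)CCCCCCCCC` gives 70700 nM, compound 3 `CCCCCCCCCCCCCCNNC(=O)COC` gives 33600 nM and compound 2 `CCCCCCCCCCCC/C=C\N(NC(=O)COC)C(=O)OC(C)(C)C` gives 15800 nM, the lowest of the three. Compound 2 is the starting point for compound 4 `CCCCCCCCCCCC/C=C/N(NC(=O)COC)C(=O)OC(C)(C)C`, and the change between them is this: the two compounds have the same atoms and bonds and differ only in configuration as drawn: 1 of 1 stereo elements differ; a double bond is drawn Z in compound 2 and E in compound 4. The double bond is thus drawn Z in compound 2 and E in compound 4, and nothing else differs.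

Only one measured step joins two of these compounds: a 4.5-fold lower number from compound 1 to compound 2 (0.65 log units; beyond the scatter). It has tert-butoxy in place of nonyl on a carbonyl carbon, and it is modest. That step bears only indirectly on the present question, since it involves a different kind of change. Among the compounds with values here, no measured pair shows what a switch of double-bond configuration does in this assay, so its size and direction remain open. With no evidence for either direction, no step beyond the scatter is expected, and the estimate stays anchored on compound 2 at 15800 nM. The expected change is a 1.1-fold higher number from compound 2 to compound 4 (0.03 log units; within the scatter). For compound 4 the estimated value is 17000 nM, with an expected range from 7500 nM to 38000 nM.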

Compound 4, concentration for 50% growth inhibition: 36100 nM
For compound 4 the middle estimate is 2.1-fold (0.33 log units) below the measured one; measured number inside the range.
By their numbers in this assay, from the lowest: compound 2; then compounds 3, 4 and 1 (each within the scatter of the next, the first and the last beyond it).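

In this assay the configuration of this double bond proves to matter, with a 2.3-fold higher number from compound 2 to compound 4 (0.36 log units; beyond the scatter), so the Z drawing keeps compound 2 the lowest of the four compounds. The step can be assigned to the double-bond configuration alone, because no other feature changes: the fact that compounds 2 and 4 differ only in the configuration as drawn. The earlier compounds had shown only that the group on the carbonyl carbon can shift the number, through a 4.5-fold lower number from compound 1 to compound 2 (0.65 log units; beyond the scatter), whereas this pair adds the configuration of the double bond as a second change that moves the number beyond the scatter.

The compounds shown leave open whether the switch from Z to E would act in the same direction and to a similar size with nonyl on the carbonyl carbon, as in compound 1, and they do not tell why the two configurations differ in growth inhibition. Going by these compounds, it also remains open how either configuration would behave with a carboxylic acid or an amine in place of the tert-butoxy group, or with a longer chain on the double bond.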